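Fluoro for trifluoromethyl on the aryl group of the series

A few compounds are considered here, and "the series" means these few. Any claim that something is new, unique, unknown or untested is made for them only; others in the source may bear on it.

Measured compounds:
compound 1, `CN1C/C(=C\c2ccncc2)C(=O)/C(=C/c2ccccc2F)C1`, 4900 nM
compound 2, `CN1C/C(=C\c2ccncc2)C(=O)/C(=C/c2ccccc2C(F)(F)F)C1`, 4500 nM
compound 3, `O=C1/C(=C/c2cccnc2)CN(S(=O)(=O)c2ccc(C(F)(F)F)cc2)C/C1=C\c1ccccc1C(F)(F)F`, 1500 nM

In a functional assay on QGY-7703 cells (Homo sapiens) for cytotoxicity, read by MTT assay, with a stated time of 24 h (a higher number here means a weaker inhibitor, a lower number a stronger inhibitor), compound 3 gives the lowest number of the three. How the core of compound 3 differs from the core of compound 2 is not broken down here. Compound 1 differs from compound 2 by fluoro in place of trifluoromethyl on an aromatic carbon; that step reads a 1.1-fold higher number from compound 2 to compound 1 (0.04 log units; within the scatter).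

Compound 4, `O=C1/C(=C/c2cccnc2)CN(S(=O)(=O)c2ccc(F)cc2)C/C1=C\c1ccccc1C(F)(F)F`, is not yet measured. It differs from compound 3 by fluoro in place of trifluoromethyl on an aromatic carbon. The change is the same kind of change as that from compound 2 to compound 1, not the same: there the fluoro stands ortho to a large group, here para to a large group. Because the earlier step was a 1.1-fold higher number from compound 2 to compound 1 (0.04 log units; within the scatter), a small step is expected, a 1.1-fold higher number from compound 3 to compound 4 (0.05 log units; within the scatter). Compound 4 is estimated at 1700 nM, expected between 800 nM and 3500 nM.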

Compound 4, half-maximal inhibitory concentration: 6030 nM
Estimate against measurement, compound 4: 3.5-fold (0.55 log units) below; measured number above the stated range.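

In this assay, the step reads a 4.0-fold higher number from compound 3 to compound 4 (0.60 log units; beyond the scatter) for 4-(trifluoromethyl)phenyl to 4-fluorophenyl, para to a large group. Fluoro in place of trifluoromethyl therefore does not carry over as one fixed step between these two cores: the same change on two cores in this assay, a 1.1-fold higher number (0.04 log units; within the scatter) from compound 2 to compound 1 and a 4.0-fold higher number (0.60 log units; beyond the scatter) from compound 3 to compound 4, 3.7-fold (0.57 log units) apart, beyond the scatter of two such steps. The pair does not separate an effect of the core from an effect of where the change sits on the aromatic ring, and two steps set no rule for further cores.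

Open, going by these compounds, is how a nitrile, a methoxy group or an amine would read in place of the trifluoromethyl lost from compound 3. Also open, on these data alone, is how fluoro would read in place of the other trifluoromethyl of compound 3, on the same core.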